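This account rests on a few compounds, and the source may have more. Where it says the series, first, only, none or still open, it means among the compounds named here.

In a functional assay on HEK293 cells for positive allosteric modulation of metabotropic glutamate receptor 5 (Homo sapiens), read by calcium flux (on this read-out lower numbers stand for smaller maximal responses and higher numbers for larger maximal responses), compound 1 `O=C1c2cc(COc3ccccc3)nn2CCN1c1ccccc1F` gives 86%, and compound 2 `O=C1c2cc(COc3ccccc3)nn2CCN1c1ccncc1` gives 72%. Of these two numbers compound 2 stands lowest, the step being a number 14 percentage points lower from compound 1 to compound 2 (beyond the scatter). Compound 3 `Cc1ccc(N2CCn3nc(COc4ccccc4)cc3C2=O)nc1` differs from compound 2 in one place: 5-methylpyridin-2-yl in place of pyridin-4-yl on an amide-type nitrogen in a ring. Among the measured compounds shown here, the only measured step that bears on this position is the one from compound 1 to compound 2, where exchanging the aromatic group on the ring nitrogen shifted the largest response modestly. For the measured compounds named here, no measured step exchanges one pyridine for another, so the direction of the present change is open; the single known step only suggests that swapping groups here moves the maximal response by a modest amount rather than a large one. A step of about a number 6 percentage points higher from compound 2 to compound 3 (within the scatter) in this assay is therefore expected, and it may well stay within the scatter. Compound 3 is estimated to reach 78%, with a range from 62% to 94%.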

Compound 3, largest response reached (Emax), in percent of the reference or control that the assay uses: 76%
Beside the measured number, compound 3's estimate is 2 percentage points above it, within the range that was stated.
By their numbers in this assay, from the lowest: compounds 2, 3 and 1 (each within the scatter of the next, the first and the last beyond it).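

In this assay, 5-methylpyridin-2-yl in place of pyridin-4-yl on the amide-type nitrogen gives a number 4 percentage points higher from compound 2 to compound 3 (within the scatter), so these two pyridines cannot be told apart on this read-out. With 5-methylpyridin-2-yl in place of 2-fluorophenyl the step is a number 10 percentage points lower from compound 1 to compound 3 (within the scatter), which means that compound 3, unlike compound 2, also cannot be told apart from compound 1. Nothing available explains these numbers.

From the compounds shown here alone, the change from compound 2 to compound 3 alters both the point of attachment of the pyridine and the methyl group at once, so the share of each remains open. A plain pyridin-2-yl would separate the two, while an amine or a carboxylic acid in place of the methyl would show whether this position accepts very different groups.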